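The source may hold more compounds than are shown below. What is called first, only, known or untested is meant among the compounds shown, and "the series" means these compounds.

Measured so far in an assay on isolated protein for inhibition of Nitric oxide synthase, inducible (Homo sapiens), with a stated time of 30 min, tested at 1 mM; on this read-out lower numbers stand for less inhibition and higher numbers for more inhibition at the one concentration tested (going by the name of the read-out):
compound 1 `CCCC(=O)N1CCC(c2ccccc2N)=N1` gives 0.35%
compound 2 `Nc1ccccc1C1=NN(C(=O)C2CC2)CC1` gives 14.8%

Among the compounds with values here, on these two numbers compound 2 stands highest in this assay, with compound 1 nearest and lower; the one measured step, a number 14.5 percentage points higher from compound 1 to compound 2 (beyond the scatter), changes only the group on the carbonyl carbon. Compound 3 `Nc1ccccc1C1=NN(C(=O)c2ccccc2)CC1` alters the same position again: phenyl in place of cyclopropyl on a carbonyl carbon. Within the data shown here, no measured step replaces one ring with another, so that single step is the only guide and it bears on the change only loosely. A step of a number 1.2 percentage points higher from compound 2 to compound 3 (within the scatter) is therefore expected, without a clear direction beyond the scatter. Compound 3 is estimated at 16%, range 3% to 35%.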

Compound 3, a percentage reported as inhibition, at one concentration (the size of the read-out at that concentration, not a potency): 8.7%
Beside the measured number, compound 3's estimate is 7.3 percentage points above it, within the range that was stated.
By their numbers in this assay, from the lowest: compounds 1, 3 and 2 (each within the scatter of the next, the first and the last beyond it).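

In this assay the phenyl group gives a number 6.1 percentage points lower from compound 2 to compound 3 (within the scatter) and a number 8.4 percentage points higher from compound 1 to compound 3 (within the scatter) on the carbonyl carbon, so compound 3 cannot be separated from either compound 1 or compound 2, although those two stand apart beyond the scatter. At this place, then, the numbers do not set phenyl apart from cyclopropyl or propyl. No measured evidence bears on this result. Open, from the compounds shown here alone, is whether a longer chain or an amine on the carbonyl carbon would give inhibition clearly apart from that of these three compounds.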